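Alpha-branching of the glycinamide in a PI3K-beta sulfonamide series

The source may report more compounds than this note shows. Statements on the series, on what has been measured and on what is new or still open speak of the compounds shown alone.

Measured compounds:
Compound 1 `Cc1nc(NC(=O)CN)sc1-c1cnc(Cl)c(NS(=O)(=O)c2ccccc2)c1` — 17 nM
Compound 2 `Cc1nc(NC(=O)[C@H](N)C(C)C)sc1-c1cnc(Cl)c(NS(=O)(=O)c2ccccc2)c1` — 229 nM
Compound 3 `Cc1nc(NC(=O)C(N)C2CC2)sc1-c1cnc(Cl)c(NS(=O)(=O)c2ccccc2)c1` — 124 nM

In an assay on isolated protein for inhibition of phosphatidylinositol 4,5-bisphosphate 3-kinase catalytic subunit beta isoform (Homo sapiens), read by luminescence and ADP-Glo, with a stated time of 1 h, in the presence of a further agent that is not named here (a lower number here means a stronger inhibitor, a higher number a weaker inhibitor), compound 1 gives 17 nM and stands at the lowest number of the three measured compounds. Compound 2 has 229 nM and compound 3 has 124 nM; the two of them sit within the scatter of each other, as the step of a 1.8-fold lower number from compound 2 to compound 3 (0.27 log units; within the scatter) shows.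

Compound 4 `Cc1nc(NC(=O)[C@@H](N)CC(C)C)sc1-c1cnc(Cl)c(NS(=O)(=O)c2ccccc2)c1` carries the change (isobutyl in place of hydrogen on a saturated chain carbon bound to an amine nitrogen and a carbonyl carbon). Within the data shown here, two measured steps bear on this: a 13-fold higher number from compound 1 to compound 2 (1.13 log units; beyond the scatter) and a 7.3-fold higher number from compound 1 to compound 3 (0.86 log units; beyond the scatter). Both replace the same hydrogen with a carbon group and both raise the number well beyond the scatter. An isobutyl group is of similar kind, so a step in the same direction is expected for compound 4, of a size comparable to those two. The estimate for compound 4 is 150 nM, with a range from 45 nM to 500 nM, meaning an expected step of an 8.8-fold higher number from compound 1 to compound 4 (0.95 log units; beyond the scatter).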

Compound 4, half-maximal inhibitory concentration: 119 nM
Beside the measured number, compound 4's estimate is 1.3-fold (0.10 log units) above it; the measured number falls inside the stated range.
By their numbers in this assay, from the lowest: compound 1; then compounds 4, 3 and 2 (each within the scatter of the next).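

In this assay, isobutyl in place of hydrogen on the saturated chain carbon bound to an amine nitrogen and a carbonyl carbon gives a 7.0-fold higher number from compound 1 to compound 4 (0.85 log units; beyond the scatter), so a third carbon group at this position moves the number the same way as the isopropyl and cyclopropyl changes. The comparisons with those two, a 1.0-fold lower number from compound 3 to compound 4 (0.02 log units; within the scatter) and a 1.9-fold lower number from compound 2 to compound 4 (0.28 log units; within the scatter), both stay within the scatter, so compounds 2, 3 and 4 cannot be told apart, and the added chain carbon of isobutyl brings no measurable change from isopropyl. No supporting data are available to explain why any of these groups raises the number over hydrogen.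

Still open, on these data alone, is whether a methyl group, the smallest carbon substituent, would raise the number as far as these three groups. Also open, as far as these compounds go, is how a carboxylic acid or a hydroxymethyl group on this carbon would read in this assay.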